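A few compounds are considered here, and "the series" means these few. Any claim that something is new, unique, unknown or untested is made for them only; others in the source may bear on it.

Compounds measured in a functional assay on the whole organism with Rattus norvegicus as the target; a lower number here means that less compound is needed, a higher number that more compound is needed for the effect:
Compound 1, `CCCCOC(=O)Oc1ccc(-c2ccc(F)cc2)cc1C(=O)O`: 25 mg/kg
Compound 2, `CCCCOC(=O)Oc1ccc(-c2ccc(F)cc2F)cc1C(=O)O`: 12 mg/kg
Compound 3, `Cc1cc(-c2ccccc2)cc(C(=O)O)c1O`: 60 mg/kg

Compound 1 and compound 2 share one core, and compound 3 has another; how the two cores differ is not broken down here. Within the first core, the change fluoro in place of hydrogen on an aromatic carbon gives a 2.1-fold lower number from compound 1 to compound 2 (0.32 log units; beyond the scatter). Compound 3 stands with the highest of the three numbers in this assay, and its nearest neighbour is compound 1.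

Compound 4, `Cc1cc(-c2ccc(F)cc2)cc(C(=O)O)c1O`, has not yet been measured in this assay. It arises from compound 3 by fluoro in place of hydrogen on an aromatic carbon. For the measured compounds named here, this is the same kind of change as the one from compound 1 to compound 2, but not the same: in compound 2 the entering fluoro sits ortho to a large group and meta to a fluoro group, whereas in compound 4 it sits para to a large group, and the cores differ.

Going by the values given here, because the one measured instance of this change gave a 2.1-fold lower number from compound 1 to compound 2 (0.32 log units; beyond the scatter), a lowering of the number is expected for compound 4 as well, though with less confidence given the different place and core. Compound 4 is estimated to reach 40 mg/kg, with a likely range from 20 mg/kg to 80 mg/kg. The expected step is a 1.5-fold lower number from compound 3 to compound 4 (0.18 log units; within the scatter).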

Compound 4, dose for half-maximal effect: 60 mg/kg
Compound 4: middle estimate off by 1.5-fold (0.18 log units), on the low side; low and high end bracket the measured number.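

In this assay, fluoro in place of hydrogen on an aromatic carbon gives no change at the digits printed from compound 3 to compound 4 (within the scatter), and set beside the earlier step, this change does not separate the two cores: the same change on two cores in this assay, a 2.1-fold lower number (0.32 log units; beyond the scatter) from compound 1 to compound 2 and no change at the digits printed (within the scatter) from compound 3 to compound 4, 2.1-fold (0.32 log units) apart, within the scatter of two such steps.

The lower number seen with the first core does not recur on the core of compound 4, yet the gap between the two steps is too small to show that the change behaves differently from one core to the other. Nor does it show that the change carries over unaltered, since each core offers only a single pair and the entering fluoro stands at a different place in each, para to a large group in compound 4, so that any influence of the core cannot be told from that of the place.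

The compounds shown leave open whether chloro or methoxy, at the same place on the core of compound 4, would move the number in this assay beyond the scatter. They also leave open whether a second fluoro on that same ring would give a clearer step on this core, so that the two cores could be compared at the same place.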